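Aryl hydrazide series, caspase-8 inhibition: naphthyl replacement

The compounds below may be only part of what the source reports. "The series", "measured", "known", "first", "only" and "open" are said of these compounds alone.

Measured so far in an assay on isolated protein for inhibition of Caspase-8 (Homo sapiens); on this read-out lower numbers stand for stronger inhibition and higher numbers for weaker inhibition:
- compound 1 `COc1cccc(C(=O)NNC(=O)C2(C(=O)N[C@H]3CC(=O)OC3O)CC2)c1`: >= 10000 nM, a limit of the assay rather than a number.
- compound 2 `COc1cccc(C(=O)NNC(=O)C2(C(=O)N[C@H]3CC(=O)OC3O)CCC2)c1`: 2200 nM.
- compound 3 `COc1cccc(C(=O)NNC(=O)C2(C(=O)N[C@H]3CC(=O)OC3O)CCCC2)c1`: 1170 nM.

Compound 3 carries the lower of the two numbers in this assay; its nearest neighbour is compound 2, whose value sits within the usual scatter of it, so no order between the two is read. For compound 1 only a limit is reported (the limit of >= 10000 nM in this assay, at which 1 of the 3 values shown sits). Compound 4 `O=C1C[C@H](NC(=O)C2(C(=O)NNC(=O)c3ccc4ccccc4c3)CCCC2)C(O)O1` is not yet measured in this assay. It differs from compound 3 by naphthalen-2-yl in place of 3-methoxyphenyl on a carbonyl carbon. Among the measured compounds shown here, no pair of measured compounds shows this exchange, so there is no measured step to lean on. The expected step is a 1.3-fold lower number from compound 3 to compound 4 (0.11 log units; within the scatter), none beyond the scatter, with a small move toward stronger inhibition not ruled out. Compound 4 is expected to give about 900 nM in this assay, with a range from 300 nM to 4000 nM.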

Compound 4, half-maximal inhibitory concentration: 3200 nM
Compound 4: middle estimate off by 3.6-fold (0.55 log units), on the low side; measured number inside the range.
By their numbers in this assay, from the lowest: compounds 3, 2 and 4 (each within the scatter of the next, the first and the last beyond it). At a limit, above all of these: compound 1.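

In this assay, among the compounds shown here, the earlier compounds all carry 3-methoxyphenyl on a carbonyl carbon whose other neighbour is an amide-type nitrogen, so they say nothing about this position. Compound 4 shows that the position responds to the group it carries, with naphthalen-2-yl in place of 3-methoxyphenyl giving a 2.7-fold higher number from compound 3 to compound 4 (0.44 log units; beyond the scatter) in the direction of weaker inhibition. The exchange adds a second six-membered aromatic ring and removes the hydrogen-bond acceptor of the leaving group, and this single pair cannot separate the two differences, while nothing shown gives a reason for the step.

A plain phenyl or a 3-hydroxyphenyl group at this position would be needed to tell those two differences apart. As far as these compounds go, whether the step carries over to the cores of compound 1 and compound 2 also remains open.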